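This account rests on a few compounds, and the source may have more. Where it says the series, first, only, none or still open, it means among the compounds named here.

Working notes on the cinnamoyl amide series. Within the data shown here, in a functional assay on DU-145 cells (Homo sapiens) for cytotoxicity, read by MTT assay, with a stated time of 72 h (a higher number here means a weaker inhibitor, a lower number a stronger inhibitor), compound 3 `COc1ccc(/C=C/C(=O)Nc2cc(C(=O)c3cc(OC)c(OC)c(OC)c3)cc(OC)c2OC)cc1OC` gives 7800 nM, the second highest of the three numbers so far. Compound 2 `COc1cc(C(=O)c2cc(OC)c(OC)c(OC)c2)cc(NC(=O)/C=C/c2cc(OC)c(OC)c(OC)c2)c1OC` gives 6600 nM, and compound 1 `COc1ccc(/C=C/C(=O)Nc2cc(C(=O)c3cc(OC)c(OC)c(OC)c3)ccc2OC)cc1` gives 12800 nM; all three values lie within the scatter of one another. The step from compound 3 to compound 4 `COc1ccc(/C=C/C(=O)Nc2cc(C(=O)c3cc(OC)c(OC)c(OC)c3)cc(OC)c2OC)cc1` is hydrogen in place of methoxy on an aromatic carbon. Among the measured compounds shown here, the one measured step of the same kind, a 1.2-fold higher number from compound 2 to compound 3 (0.07 log units; within the scatter), stayed within the scatter, and compound 1, which carries the same 4-methoxyphenyl group on a different core, gives a number within the scatter of compound 3 as well. No shift beyond the scatter is therefore expected in this assay; for compound 4 the expected step is a 1.1-fold higher number from compound 3 to compound 4 (0.04 log units; within the scatter). Compound 4 is estimated at 8500 nM, in the range 4000 nM to 18000 nM.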

Compound 4, half-maximal inhibitory concentration: 10400 nM
Estimate against measurement, compound 4: 1.2-fold (0.09 log units) below, and the stated range covers the measured number.
By their numbers in this assay, from the lowest: compounds 2, 3, 4 and 1 (each within the scatter of the next).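

In this assay, hydrogen in place of methoxy on the 3,4-dimethoxyphenyl group gives a 1.3-fold higher number from compound 3 to compound 4 (0.12 log units; within the scatter), and 4-methoxyphenyl in place of 3,4,5-trimethoxyphenyl gives a 1.6-fold higher number from compound 2 to compound 4 (0.20 log units; within the scatter), so neither change moves the number beyond the scatter. Methoxy in place of hydrogen on an aromatic carbon of the core of compound 1 gives a 1.2-fold lower number from compound 1 to compound 4 (0.09 log units; within the scatter), also within the scatter. The methoxy-to-hydrogen change now reads alike in two settings: the same change on two cores in this assay, a 1.2-fold higher number (0.07 log units; within the scatter) from compound 2 to compound 3 and a 1.2-fold higher number (0.09 log units; within the scatter) from compound 4 to compound 1, 1.0-fold (0.02 log units) apart, within the scatter of two such steps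

Going by these compounds, whether another group at this place, such as an amine, a hydroxyl or a chlorine, would shift the number beyond the scatter stays open.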